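The source may report more compounds than this note shows. Statements on the series, on what has been measured and on what is new or still open speak of the compounds shown alone.

Measured compounds:
compound 1 `Oc1ccc2ccccc2c1/C=N/NC(=S)Nc1ccccc1` gives 600 nM in a functional assay on WI-38 cells (Homo sapiens) for antiproliferative activity, read by MTT assay, with a stated time of 72 h; a lower number here means a stronger inhibitor, a higher number a weaker inhibitor;
compound 2 `CCN(CC)c1ccc(/C=N/NC(N)=S)c(O)c1` gives 200 nM in this assay.

Of the two numbers, compound 2 has the lower one; compound 1 has the higher one, and the gap between them lies beyond the scatter, so compound 2 is the stronger inhibitor of the pair. Compound 3 `CCN(CC)c1ccc(/C=N/NC(=S)Nc2ccccc2)c(O)c1` has not yet been measured. It keeps the core of compound 2 and differs from it in one place: phenyl in place of hydrogen on an amide-type nitrogen. Within the data shown here, no measured pair isolates this particular change, so its effect can only be guessed. Compound 1 carries the same phenyl on that nitrogen but on a different core, and its higher number gives no clean reading of the change. A small step is expected, a 1.5-fold higher number from compound 2 to compound 3 (0.18 log units; within the scatter), most likely within the scatter or slightly toward a weaker inhibitor. Compound 3 is therefore estimated at 300 nM, with a range from 100 nM to 900 nM.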

Compound 3, half-maximal inhibitory concentration: 300 nM
Estimate against measurement, compound 3: no gap at the digits printed, and the stated range covers the measured number.
By their numbers in this assay, from the lowest: compounds 2, 3 and 1 (each within the scatter of the next, the first and the last beyond it).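

In this assay the change from amino to anilino now has a reading of its own on the shared core, with a 1.5-fold higher number from compound 2 to compound 3 (0.18 log units; within the scatter) for phenyl in place of hydrogen on the amide-type nitrogen. The earlier compounds shown here could not isolate this change, as compound 1 carries the same phenyl on a different core. At this nitrogen, whose other neighbour is the thiocarbonyl carbon, the two numbers cannot be told apart, so the phenyl brings no step beyond the scatter, and nothing at hand explains this outcome.

The compounds shown leave open whether a smaller or more flexible group at this nitrogen, such as methyl or benzyl, would behave the same way. They also leave open whether a phenyl bearing an amine or a carboxylic acid would keep the number of compound 3.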